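Notes on an aryl change at the saturated ring carbon

The source may hold more compounds than are shown below. What is called first, only, known or untested is meant among the compounds shown, and "the series" means these compounds.

Compound 1 `N#CC1=C(N)OC(c2c[nH]c3ccccc23)=C(C#N)C1c1ccccc1F` was tested in a functional assay, tested at 50 ug/mL (a lower number here means a weaker effect, a higher number a stronger effect of the compound at the concentration tested), and comes back as "not active" (no number reported), so no single number is available for it; compound 2 `N#CC1=C(N)OC(c2c[nH]c3ccccc23)=C(C#N)C1c1ccc2ccccc2c1` likewise returns "not active" (no number reported) in this assay. For the measured compounds named here, the only compound of the set with a number is compound 3 `CN(C)c1ccc(C2C(C#N)=C(N)OC(c3c[nH]c4ccccc34)=C2C#N)cc1`, which gives 14.4% in this assay. Compound 1 therefore stands at the bottom of what has been seen so far, sharing that standing with one further entry that also has no number.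

Compound 4 `COc1ccc(C2C(C#N)=C(N)OC(c3c[nH]c4ccccc34)=C2C#N)cc1` has not yet been measured. Its difference from compound 1 is 4-methoxyphenyl in place of 2-fluorophenyl on a saturated ring carbon. Going by the values given here, no step between two measured compounds is available to size such a change, so any expectation rests on the three readings alone. The readings of compound 1 and compound 2 without a number, and the reading of compound 3 with 14.4%, leave room for a small step upward from compound 1 to compound 4 in this assay, of a size at or near the scatter of the assay, or none at all. Compound 4 is accordingly expected to give about 10% in this assay, with a range from 0% to 25%. Among the compounds with values here, the estimate leans on compound 3, whose reading of 14.4% in this assay is the only number to hand.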

Compound 4, a percentage reported as activity, at one concentration (the size of the read-out at that concentration, not a potency): 12.4%
Compound 4: the middle estimate sits 2.4 percentage points below what was measured; low and high end bracket the measured number.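

Methoxy in place of dimethylamino on an aromatic carbon gives a number 2 percentage points lower from compound 3 to compound 4 (within the scatter) in this assay, so the two groups cannot be told apart in this read-out. On the saturated ring carbon, compound 4 with 4-methoxyphenyl gives 12.4% while compound 1 with 2-fluorophenyl gives "not active" (no number reported) and no step can be read between this pair, though they differ in that one place only. Among the four compounds, a number appears only where the phenyl carries methoxy or dimethylamino, a pattern that rests on just compound 3 and compound 4 and that neither compound 1 nor compound 2 tests directly.

Open, on these data alone, is whether 4-fluorophenyl or unsubstituted phenyl at this carbon would return a number in this assay and whether a carboxylic acid on the phenyl would do the same, which would separate the effect of the group from that of its place on the ring. No measurement beyond these readings is at hand to account for any of them.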